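This account rests on a few compounds, and the source may have more. Where it says the series, first, only, none or still open, it means among the compounds named here.

- compound 1 `CC(C)(C)c1ccc(S(=O)(=O)n2cnc3ccccc32)cc1`: 68500 nM
- compound 2 `O=S(=O)(c1ccc(C(F)(F)F)cc1)n1cnc2ccccc21`: 460000 nM
- compound 3 `O=S(=O)(c1cccc(C(F)(F)F)c1)n1cnc2ccccc21`: 59800 nM

In an ADME assay on Vero cells (Chlorocebus sabaeus) for cytotoxicity, read by flow cytometry and propidium iodide staining, with a stated time of 72 h (on this read-out higher numbers stand for weaker inhibition and lower numbers for stronger inhibition), compound 2 has the highest of the three numbers, and both other compounds lie well below it. The next compound to be measured is compound 4 `O=S(=O)(c1ccc(Br)cc1)n1cnc2ccccc21`, which differs from compound 2 as follows: bromo in place of trifluoromethyl on an aromatic carbon. It carries bromo in place of trifluoromethyl on an aromatic carbon. Within the data shown here, only one measured step changes a group at this place: a 6.7-fold higher number from compound 1 to compound 2 (0.83 log units; beyond the scatter). Among the measured compounds shown here, no measured compound carries bromo, so this step is only a rough guide to size. Since compound 2 stands apart at 460000 nM, a move back towards the other compounds seems likely, to a lower number. The expected change is a 3.1-fold lower number from compound 2 to compound 4 (0.49 log units; beyond the scatter). For compound 4 the estimate is 150000 nM, with an expected range of 50000 nM to 400000 nM.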

Compound 4, half-maximal inhibitory concentration: 1190000 nM
Compound 4: the middle estimate sits 7.9-fold (0.90 log units) below what was measured; the whole stated range lies below it.
By their numbers in this assay, from the lowest: compounds 3 and 1 (each within the scatter of the next); then compound 2; then compound 4.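

In this assay, the number at this place on the aromatic ring can climb further than trifluoromethyl took it: the change to bromo gives a 2.6-fold higher number from compound 2 to compound 4 (0.41 log units; beyond the scatter), and bromo in place of tert-butyl gives a 17-fold higher number from compound 1 to compound 4 (1.24 log units; beyond the scatter). The order here, from lowest number to highest, is tert-butyl, trifluoromethyl, bromo, so the single heavy atom of bromo gives a higher number than the four of trifluoromethyl. No measurement here explains this order. On these data alone, how an amine or a carboxylic acid at this place would read remains open, as does whether bromo would give the same result elsewhere on the ring.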